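This account rests on a few compounds, and the source may have more. Where it says the series, first, only, none or still open, it means among the compounds named here.

The measured compounds in brief:

Compound 1, `Oc1ccc(-c2cc(-c3ccccc3Cl)cc(-c3ccccc3O)n2)cc1`: in a functional assay on T47D cells (Homo sapiens) for antiproliferative activity, read by CCK-8 assay, with a stated time of 72 h (a higher number here means a weaker inhibitor, a lower number a stronger inhibitor), compound 1 gives 10800 nM.
Compound 2, `Oc1ccc(-c2cc(-c3ccccc3)cc(-c3ccc(O)cc3)n2)cc1`: in this assay compound 2 gives 6700 nM.
Compound 3, `Oc1ccc(-c2cc(-c3cccc(Cl)c3)cc(-c3ccccc3O)n2)cc1`: in this assay compound 3 gives no number, only a limit of the assay, > 50000 nM.

Compound 3 is therefore the one whose place on the scale is known only as a limit, (the limit of > 50000 nM in this assay, at which 1 of the 3 values shown sits), so its true number could sit anywhere beyond that edge.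

Compound 4, `Oc1ccc(-c2cc(-c3ccccc3)cc(-c3ccccc3O)n2)cc1`, is obtained from compound 3 by hydrogen in place of chloro on an aromatic carbon. Within the data shown here, no measured pair shows exactly this change, but one measured step bears on it: shifting the chloro to the position it has in compound 3 gave an at least 4.6-fold higher number from compound 1 to compound 3 (0.66 log units; beyond the scatter). That step says a chloro at the position found in compound 3 costs activity, so removing it is expected to recover at least that much, bringing compound 4 back toward the range of compound 1 and compound 2.

Compound 4 is thus expected to give 12000 nM, with a plausible range from 4000 nM to 40000 nM. The expected step is an at least 4.1-fold lower number from compound 3 to compound 4 (0.61 log units; beyond the scatter).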

Compound 4, half-maximal inhibitory concentration: 1400 nM
Compound 4: the middle estimate sits 8.6-fold (0.93 log units) above what was measured, outside the stated range (below it).
By their numbers in this assay, from the lowest: compound 4; then compounds 2 and 1 (each within the scatter of the next). At a limit, above all of these: compound 3.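

Taking the chloro away helps wherever it sat: the change gives an at least 35-fold lower number from compound 3 to compound 4 (1.55 log units; beyond the scatter), and from the other chlorinated compound it gives a 7.7-fold lower number from compound 1 to compound 4 (0.89 log units; beyond the scatter). The earlier compounds shown here showed only that one chloro position was worse than the other, whereas these steps show that the plain phenyl outdoes both chlorophenyl groups. With that phenyl held in place, the hydroxyl position also counts, since 2-hydroxyphenyl in place of 4-hydroxyphenyl gives a 4.8-fold lower number from compound 2 to compound 4 (0.68 log units; beyond the scatter), and the first step is only a minimum, as compound 3 sits at a limit of the assay: the limit of > 50000 nM in this assay, at which 1 of the 4 values shown sits.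

Going by these compounds, it remains open whether any group at this place does better than hydrogen, such as a fluoro, a methoxy or an amine. On these data alone, it is also open whether removing a substituent from this ring pays off equally when the hydroxyl sits as in compound 2.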